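The source may report more compounds than this note shows. Statements on the series, on what has been measured and on what is new or still open speak of the compounds shown alone.

Measured compounds:
- compound 1, `CCOC(=O)C1(CCCCCc2ccc(Cl)cc2)CO1`: 20 umol/kg
- compound 2, `CCOC(=O)C1(CCCc2ccccc2)CO1`: 1170 umol/kg
- compound 3, `CCOC(=O)C1(CCCc2ccc(Cl)c(Cl)c2)CO1`: 330 umol/kg

All three were tested in a functional assay on the whole organism (blood) with Rattus norvegicus as the target; a lower number here means that less compound is needed, a higher number that more compound is needed for the effect. Among them compound 1 stands with the lowest number; compound 3 comes nearest, with a number that is still well beyond the scatter above it, and compound 2 lies furthest away. Among the measured compounds shown here, compound 1 is therefore the compound from which the least is needed in this assay among the three measured so far.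

The next compound to be measured is compound 4, `O=C(O)C1(CCCCCc2ccc(Cl)cc2)CO1`. It differs from compound 1 in one place: hydrogen in place of ethyl on an oxygen next to a carbonyl group. Put another way, the ethoxycarbonyl group of compound 1 becomes a carboxy group in compound 4.

For the measured compounds named here, no pair of measured compounds shows this change, so the measured numbers give no direct guide to its size. The expectation therefore rests on compound 1 alone. An estimated step of a 2.5-fold higher number from compound 1 to compound 4 (0.40 log units; beyond the scatter) is expected, leaning towards a higher number, though it may well turn out to lie within the scatter. Compound 4 is expected to give about 50 umol/kg in this assay, with a plausible range from 8 umol/kg to 300 umol/kg.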

Compound 4, dose for half-maximal effect: 30 umol/kg
Beside the measured number, compound 4's estimate is 1.7-fold (0.22 log units) above it; measured number inside the range.
By their numbers in this assay, from the lowest: compounds 1 and 4 (each within the scatter of the next); then compound 3; then compound 2.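

In this assay, among the compounds shown here, this is the first pair of measured compounds that differ in one place, and it gives a 1.5-fold higher number from compound 1 to compound 4 (0.18 log units; within the scatter). The ethoxycarbonyl group and the carboxy group therefore cannot be told apart at this position in this whole-animal read-out, which means that the ethyl on this oxygen is not required for the low dose seen with compound 1. Nothing available explains why the two compounds give such similar numbers.

The compounds shown leave open whether other groups at this position, such as an amide or a methyl ester, would also stay within the scatter of compound 1, and whether the same swap of ethoxycarbonyl to carboxy would behave alike on the chains of compound 2 and compound 3. They also leave open what the chain and the chlorine substituents each contribute, as compound 1 differs from compound 2 and from compound 3 in more than one place, so no single step can be read from those pairs.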